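The source may hold more compounds than are shown below. What is called first, only, known or untested is meant among the compounds shown, and "the series" means these compounds.

In an assay on a protein complex for inhibition of CDK8/Cyclin C (Homo sapiens), with a stated time of 1 h (on this read-out lower numbers stand for stronger inhibition and higher numbers for weaker inhibition), compound 1, `CNC(=O)/C=C/c1ccncc1-c1ccc2cc[nH]c2c1`, gives 18.6 nM. Compound 3, `CN(C)C(=O)/C=C/c1ccncc1-c1ccc2ccccc2c1`, gives 30.1 nM in this assay. Compound 2, `CNC(=O)/C=C/c1ccncc1-c1ccc2cnn(C)c2c1`, gives 122 nM in this assay, which is the highest of the three numbers and so marks compound 2 as the weakest inhibitor of the set; compound 3 stands nearest to it and compound 1 furthest, and both of those gaps lie beyond the usual scatter of repeated measurements.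

Compound 4, `Cn1ncc2ccc(-c3cnccc3/C=C/C(=O)N3CCOCC3)cc21`, has not yet been measured. It differs from compound 2 in a single place: morpholin-4-yl in place of methylamino on a carbonyl carbon. Among the measured compounds shown here, no measured pair in this set carries that same change, so its effect cannot be read off directly. With the compounds at hand, the expected step from compound 2 to compound 4 in this assay is small, a 1.2-fold higher number from compound 2 to compound 4 (0.09 log units; within the scatter), and may not reach beyond the scatter in either direction. Compound 4 is therefore estimated at 150 nM, with a range from 50 nM to 450 nM.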

Compound 4, half-maximal inhibitory concentration: 853 nM
Compound 4: the middle estimate sits 5.7-fold (0.75 log units) below what was measured; the whole stated range lies below it.
By their numbers in this assay, from the lowest: compounds 1 and 3 (each within the scatter of the next); then compound 2; then compound 4.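

Among the compounds shown here, this is the first step in the set that changes only the group on the carbonyl carbon. In this assay, morpholin-4-yl in place of methylamino gives a 7.0-fold higher number from compound 2 to compound 4 (0.84 log units; beyond the scatter), so on this core the read-out clearly depends on which group sits at this position. Nothing among the data shown explains why the number rises.

The change removes the amide hydrogen and brings in a six-membered ring with an oxygen, all in one step, so the compounds shown leave open which of these matters. On the same core, a piperidin-1-yl group would carry a six-membered ring without the oxygen and an ethylamino group would keep the amide hydrogen with a longer chain, and either could help to pull these features apart.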